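The source may hold more compounds than are shown below. What is called first, only, known or untested is meant among the compounds shown, and "the series" means these compounds.

Compounds measured so far: compound 1, `c1ccc(-c2ccc3[nH]ncc3c2)cc1`, and compound 2, `CC(C)(C)c1ccccc1-c1ccc2[nH]ncc2c1`.

In an assay on CHO-TREX cells for antagonist activity at transient receptor potential cation channel subfamily A member 1 (Homo sapiens), read by FLIPR and calcium flux, with a stated time of 10 min (a higher number here means a weaker inhibitor, a lower number a stronger inhibitor), compound 1 gives > 30000 nM, which is a limit of the assay. In this assay compound 2 gives 3400 nM, the only number shown here. Compound 3, `FC(F)c1ccccc1-c1ccc2[nH]ncc2c1`, differs from compound 2 by difluoromethyl in place of tert-butyl on an aromatic carbon. Among the measured compounds shown here, the one measured step at this place is an at least 8.8-fold lower number from compound 1 to compound 2 (0.94 log units; beyond the scatter). With the tert-butyl gone, compound 3 is expected to sit between the two measured compounds, estimated at 10000 nM, in the range 3000 nM to 40000 nM. The expected step is a 2.9-fold higher number from compound 2 to compound 3 (0.47 log units; beyond the scatter).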

Compound 3, half-maximal inhibitory concentration: 2200 nM
Beside the measured number, compound 3's estimate is 4.5-fold (0.66 log units) above it, outside the stated range (below it).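

In this assay, among the compounds shown here, tert-butyl is not the only group at this place that goes with a measurable number: with difluoromethyl there is a 1.5-fold lower number from compound 2 to compound 3 (0.19 log units; within the scatter), so the two groups cannot be told apart. Against hydrogen, the change to difluoromethyl gives an at least 13-fold lower number from compound 1 to compound 3 (1.13 log units; beyond the scatter). That step is only a bound, because compound 1 stands at a limit of the assay: the limit of > 30000 nM in this assay, at which 1 of the 3 values shown sits.

From the compounds shown here alone, whether a methyl, an amine or a carboxylic acid at this place would go with a similar number stays open. So does whether difluoromethyl would do the same elsewhere on that ring.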